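The compounds below may be only part of what the source reports. "The series", "measured", "known", "first", "only" and "open" are said of these compounds alone.

In a functional assay on DLD-1 cells (Homo sapiens) for cytotoxicity, read by MTT assay, with a stated time of 48 h (on this read-out lower numbers stand for stronger inhibition and higher numbers for weaker inhibition), compound 3 `COc1ccc(-c2cn(/N=C/c3cc4cc(C)ccc4nc3Cl)c(N)n2)cc1` gives 25700 nM, the highest of the two numbers recorded here. Compound 2 `Cc1ccc2nc(Cl)c(/C=N/n3cc(-c4ccccc4)nc3N)cc2c1` gives 8790 nM. Compound 1 `COc1ccc(-c2cn(/N=C/c3cc4ccccc4nc3Cl)c(N)n2)cc1` reaches only the limit of this assay, > 50000 nM. Compound 4 `Cc1ccc2nc(Cl)c(/C=N/n3cc(-c4ccc5ccccc5c4)nc3N)cc2c1` differs from compound 3 by naphthalen-2-yl in place of 4-methoxyphenyl on an aromatic carbon. Going by the values given here, two measured steps bear on this change. a 2.9-fold higher number from compound 2 to compound 3 (0.47 log units; beyond the scatter) shows the number rising when methoxy enters, and an at least 1.9-fold lower number from compound 1 to compound 3 (0.28 log units; that floor lies within the scatter) lies within the scatter. Among the compounds with values here, the loss of the methoxy group in compound 4 reverses the change seen in a 2.9-fold higher number from compound 2 to compound 3 (0.47 log units; beyond the scatter); the fused second ring has no measured counterpart here. A modestly lower number is therefore expected, and a 2.9-fold lower number from compound 3 to compound 4 (0.46 log units; beyond the scatter) is the estimated step. Compound 4 is estimated at 9000 nM, with a likely range from 3000 nM to 30000 nM.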

Compound 4, half-maximal inhibitory concentration: 10200 nM
Compound 4: the middle estimate sits 1.1-fold (0.05 log units) below what was measured, and the stated range covers the measured number.
By their numbers in this assay, from the lowest: compounds 2 and 4 (each within the scatter of the next); then compound 3. At a limit, above all of these: compound 1.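

In this assay, replacing 4-methoxyphenyl gives a 2.5-fold lower number from compound 3 to compound 4 (0.40 log units; beyond the scatter), so this aromatic carbon of the five-membered ring holds naphthalen-2-yl without the number rising. Going by these compounds alone, measured against plain phenyl, the fused second ring gives a 1.2-fold higher number from compound 2 to compound 4 (0.06 log units; within the scatter), so the larger group leaves the number level with that of phenyl, something the earlier compounds could not show.

From the compounds shown here alone, how a small amine or a carboxylic acid would behave on this carbon, in place of an aromatic ring, stays open. Nothing given here explains either step.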